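Swapping the benzyl substituent on a bromoacrylamide scaffold

A few compounds are considered here, and "the series" means these few. Any claim that something is new, unique, unknown or untested is made for them only; others in the source may bear on it.

Compound 2 `C=C(Br)C(=O)Nc1cccc(-c2cn3nc(Cc4cccc(OC)c4)sc3n2)c1` is the reference point here. In a functional assay on HeLa cells (Homo sapiens) for inhibition, read by cell counting, with a stated time of 4 days (a lower number here means a stronger inhibitor, a higher number a weaker inhibitor), compound 2 gives 2500 nM, which is the second highest of the three measured numbers. Compound 1 `C=C(Br)C(=O)Nc1cccc(-c2cn3c(-c4ccc(OC)cc4)csc3n2)c1` is its nearest neighbour: in this assay compound 1 gives 860 nM, a gap beyond the scatter. Compound 3 `COc1cccc(Cc2nn3cc(-c4cccc(N)c4)nc3s2)c1` is furthest away, and in this assay compound 3 gives 24000 nM. Among the compounds with values here, the single step between measured compounds differing in one place is a 9.6-fold higher number from compound 2 to compound 3 (0.98 log units; beyond the scatter), which concerns hydrogen in place of (1-bromoethenyl)carbonyl on a nitrogen on an aromatic ring.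

Compound 4 `C=C(Br)C(=O)Nc1cccc(-c2cn3nc(Cc4ccc(Cl)cc4)sc3n2)c1` differs from compound 2 by 4-chlorophenyl in place of 3-methoxyphenyl on a saturated chain carbon bound to an aromatic carbon. Within the data shown here, no measured step touches this part of the molecule, so the data give no direct guide to the direction or size of the change. On that basis the step of no change at the digits printed from compound 2 to compound 4 (within the scatter) is expected to be none beyond the scatter. Compound 4 is therefore estimated at 2500 nM, within a range from 800 nM to 8000 nM.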

Compound 4, half-maximal inhibitory concentration: 2700 nM
Estimate against measurement, compound 4: 1.1-fold (0.03 log units) below; the range from low to high includes it.
By their numbers in this assay, from the lowest: compound 1; then compounds 2 and 4 (each within the scatter of the next); then compound 3.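

In this assay, within the data shown here, the step of a 1.1-fold higher number from compound 2 to compound 4 (0.03 log units; within the scatter) lies within the scatter, and it is the first measured step at this position, the saturated chain carbon bound to an aromatic carbon. It shows that 4-chlorophenyl in place of 3-methoxyphenyl leaves the number unchanged within the scatter while the bromoacrylamide stays in place, so this single swap at this position gives no readable effect on the number. No measurement available here speaks to what lies behind this result.

This one pair changes the substituent and its printed ring position together, so the contribution of each stays unresolved. As far as these compounds go, whether 4-methoxyphenyl, an amine or a carboxylic acid on this ring, or a longer chain in place of the benzyl link, would also leave the number within the scatter remains open.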